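The source may hold more compounds than are shown below. What is called first, only, known or untested is meant among the compounds shown, and "the series" means these compounds.

In a functional assay on HepG2 cells (Homo sapiens) for antiproliferative activity, with a stated time of 72 h (on this read-out lower numbers stand for an effect already at smaller amounts and higher numbers for an effect only at larger amounts of compound), compound 1 `COc1ccc(-c2[nH]c3cc(OC)cc(OC)c3c(=O)c2I)cc1` gives > 86200 nM, which is a limit of the assay and not a number. Compound 2 `COc1ccc(-c2c(I)c(=O)c3c(OC)cc(OC)cc3n2S(=O)(=O)c2ccc(OC)cc2)cc1` in this assay gives > 17300 nM, also a limit. The step that the two limits leave unreadable from compound 1 to compound 2 therefore cannot be read. Compound 3 `COc1ccc(-c2cc(=O)c3c(OC)cc(OC)cc3n2S(=O)(=O)c2ccc([N+](=O)[O-])cc2)cc1` in this assay gives > 29300 nM, again a limit; all three values shown are limits, so compound 3 stands level with the rest without a readable number. Compound 4 `COc1ccc(-c2cc(=O)c3c(OC)cc(OC)cc3n2S(=O)(=O)c2cccc(Br)c2)cc1` differs from compound 3 by 3-bromophenyl in place of 4-nitrophenyl on a sulfonyl sulfur. No measured step touches the group on the sulfonyl sulfur, and the only shown step is unreadable, so no step beyond the scatter is expected in either direction in this assay. Compound 4 is expected to give 50000 nM, within 15000 nM to 150000 nM, most likely again as a limit. The step that the limit leaves unreadable from compound 3 to compound 4 is expected to be small.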

Compound 4, half-maximal effective concentration: > 58600 nM
Compound 4 was reported as a limit (the forecaster's own chance of this, stated with the estimate: 75%); middle value at least 1.1-fold (0.06 log units) away from the limit.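

Compound 3 gives > 29300 nM, a limit. Compound 4 gives > 58600 nM, also a limit, so no step can be read from compound 3 to compound 4. The compounds shown leave open whether any group on the sulfonyl sulfur gives a readable value in this assay.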